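A few compounds are considered here, and "the series" means these few. Any claim that something is new, unique, unknown or untested is made for them only; others in the source may bear on it.

Working notes on a pair of sulfonamides sharing one core. Compound 1 `Cc1ccccc1S(=O)(=O)Nc1ccc2oc(-c3ccccc3)nc2c1` was tested in an ADME assay on HEK293 cells (Homo sapiens) for cytotoxicity, read by resazurin assay, with a stated time of 48 h (on this read-out higher numbers stand for lower toxicity in this test and lower numbers for higher toxicity in this test), where compound 1 gives 57000 nM. Compound 2 `CCc1ccc(S(=O)(=O)Nc2ccc(-c3nc4ccccc4o3)cc2)cc1` carries its sulfonamide on a different position of the shared core, and in this assay compound 2 gives 82000 nM. Compound 1 stands on the lower of the two numbers, but the gap to compound 2 lies within the scatter of this kind of measurement, so the two compounds cannot be told apart in toxicity on these data.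

Compound 3 `Cc1cccc(S(=O)(=O)Nc2ccc3oc(-c4ccccc4)nc3c2)c1` has not yet been measured in this assay. It differs from compound 1 in one place: 3-methylphenyl in place of 2-methylphenyl on a sulfonyl sulfur. Within the data shown here, no measured pair in this set shows the effect of moving a methyl around that ring, so the step has to be judged from the size of the change alone, which is small and keeps every counted feature the same.

For compound 3 a result close to that of compound 1 is expected, with a step of a 1.1-fold higher number from compound 1 to compound 3 (0.02 log units; within the scatter) that stays within the scatter. The estimate for compound 3 in this assay is 60000 nM, with a range of 30000 nM to 120000 nM.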

Compound 3, half-maximal cytotoxic concentration: 69000 nM
For compound 3 the middle estimate is 1.2-fold (0.06 log units) below the measured one; measured number inside the range.
By their numbers in this assay, from the lowest: compounds 1, 3 and 2 (each within the scatter of the next).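

Among these compounds, replacing 2-methylphenyl with 3-methylphenyl on a sulfonyl sulfur gives the first measured single-place step in this set: in this assay there is a 1.2-fold higher number from compound 1 to compound 3 (0.08 log units; within the scatter). For this pair, relocating the methyl on that ring therefore produces no difference that can be told apart from the scatter, whereas the earlier data could offer only a judgement from the size of the change. No measured finding bears on the reason for this outcome, so the result stands as an observation for this one pair.

The compounds shown leave open whether a group other than methyl on this ring, such as an amine, a carboxylic acid or a longer chain, would give a step beyond the scatter in this assay. Also open, on these data alone, is whether replacing the whole aromatic ring on the sulfonyl sulfur with a saturated carbon ring, or making a single change elsewhere on the shared core, would separate a compound from compound 1 in this test.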